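Compound 2 to compound 3: one group exchanged at a limit

A few compounds are considered here, and "the series" means these few. Any claim that something is new, unique, unknown or untested is made for them only; others in the source may bear on it.

Measured so far in a functional assay on HEK293 cells (Homo sapiens) for cytotoxicity; a lower number here means that less compound is tolerated, a higher number that more compound is tolerated:
- Compound 1 `COc1ccc([C@H]2CC(=O)N(Cc3cccc(C#N)c3)C2)cc1OC1CCCC1`: > 10000 nM, a limit
- Compound 2 `COc1ccc([C@H]2CC(=O)N(c3ccc(C)c(N)c3)C2)cc1OC1CCCC1`: > 10000 nM, a limit

Compound 2 gives > 10000 nM in this assay, and this is a limit of the assay, not a number. It therefore cannot be placed exactly, and the same holds for the other measured compound: the limit of > 10000 nM in this assay, at which 2 of the 2 values shown sit.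

The next compound, compound 3 `COc1ccc([C@H]2CC(=O)N(c3ccccc3N)C2)cc1OC1CCCC1`, keeps the shared core. The change is 2-aminophenyl in place of 3-amino-4-methylphenyl on an amide-type nitrogen in a ring.

Among the measured compounds shown here, only one measured step bears on this change, and it also concerns the group on that nitrogen: a step that the two limits leave unreadable from compound 1 to compound 2. That step offers no size to carry over. For the measured compounds named here, with a step that the two limits leave unreadable from compound 1 to compound 2 as the only guide, no step beyond the usual scatter is expected in this assay, in either direction, and another limit is the most likely report. The expected step is a step that the limit leaves unreadable from compound 2 to compound 3. Compound 3 is estimated at 15000 nM, with an expected range from 7000 nM to 30000 nM.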

Compound 3, half-maximal cytotoxic concentration: > 10000 nM
Compound 3: no number, only a limit; the forecaster's own chance of this, stated with the estimate: 85%; the middle value is on the limit's open side.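

No step can be read between compound 1, compound 2 and compound 3 in this assay, as each gives a limit of the assay rather than a number: the limit of > 10000 nM in this assay, at which 3 of the 3 values shown sit. From the compounds shown here alone, what stays open is how far the tolerated concentration of each compound lies past this limit, and whether the group on the nitrogen changes it at all.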